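Trifluoromethylcyclopropyl Analogue of a Compound Already at the Limit

The source may report more compounds than this note shows. Statements on the series, on what has been measured and on what is new or still open speak of the compounds shown alone.

Measured compounds:
compound 1, `Cc1cc(NC(=O)Cn2nnc(-c3ccccc3)n2)n(C2CCCCC2)n1`: 96 nM
compound 2, `CC1CC1c1cc(NC(=O)Cn2nnc(-c3ccccc3)n2)n(C2CCCCC2)n1`: 843 nM
compound 3, `CC1(c2cc(NC(=O)Cn3nnc(-c4ccccc4)n3)n(C3CCCCC3)n2)CC1`: > 10000 nM

In an assay on HEK293 cells for activation of Kir3.1/Kir3.2 (Homo sapiens), read by thallium flux (a higher number here means that more compound is needed for the effect, a lower number that less compound is needed), compound 1 gives 96 nM and compound 2 gives 843 nM. For compound 3 the assay reports only a limit, > 10000 nM. Compound 3 thus sits at the limit of > 10000 nM in this assay, at which 1 of the 3 values shown sits, the highest of the three, reached through an at least 100-fold higher number from compound 1 to compound 3 (2.01 log units; beyond the scatter) and an at least 11-fold higher number from compound 2 to compound 3 (1.07 log units; beyond the scatter). Compound 4 `O=C(Cn1nnc(-c2ccccc2)n1)Nc1cc(C2(C(F)(F)F)CC2)nn1C1CCCCC1` differs from compound 3 by trifluoromethyl in place of methyl on a saturated ring carbon. Within the data shown here, no measured step exchanges methyl for trifluoromethyl on a saturated ring carbon, so the only guide is the limit at which compound 3 stands. Compound 4 is therefore expected to stay at or beyond that limit, an estimated step that the limit leaves unreadable from compound 3 to compound 4. The estimate for compound 4 in this assay is 15000 nM, with a range of 3000 nM to 60000 nM.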

Compound 4, half-maximal effective concentration: "not active" (no number reported)
Compound 4: no number reported; there is nothing to compare the estimate with.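

Among these compounds, compound 4 is reported only as not active, without a number, and compound 3 stands at a limit, so no step from compound 3 to compound 4 can be read. The compounds shown leave open what trifluoromethyl in place of methyl on a saturated ring carbon does to the measured concentration.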